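Chloro in Place of Hydrogen, Tried on a Second Core

This account rests on a few compounds, and the source may have more. Where it says the series, first, only, none or still open, it means among the compounds named here.

Of the compounds shown here, three have been measured in a functional assay on U-87MG ATCC cells for antiproliferative activity against U-87 MG (Homo sapiens), read by MTT assay, with a stated time of 48 h; a higher number here means a weaker inhibitor, a lower number a stronger inhibitor. Compound 1 `COc1ccc(-c2nc(C)c(C(=O)CSc3nc(N)c(C#N)c(-c4ccc(Cl)cc4)n3)s2)cc1` gives 4540 nM, and compound 2 `COc1ccc(-c2nc(C)c(C(=O)CSc3nc(N)c(C#N)c(-c4ccccc4)n3)s2)cc1` gives 8540 nM; the two share one core and differ in a single place, the change from compound 2 to compound 1 being (chloro in place of hydrogen on an aromatic carbon), which made a step of a 1.9-fold lower number from compound 2 to compound 1 (0.27 log units; within the scatter). Compound 3 `COc1ccc(-c2nc(SCC(=O)c3sc(-c4ccccc4)nc3C)[nH]c(=O)c2C#N)cc1OC` carries a different core; in this assay compound 3 gives 15300 nM, the highest of the three numbers. The difference between the core of compound 3 and that of compound 2 is not broken down here.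

Compound 4 `COc1ccc(-c2nc(SCC(=O)c3sc(-c4ccc(Cl)cc4)nc3C)[nH]c(=O)c2C#N)cc1OC` is not yet measured. It differs from compound 3 by chloro in place of hydrogen on an aromatic carbon, the same change as that from compound 2 to compound 1, at a place described in the same words. On the core of compound 2 that change gave only a 1.9-fold lower number from compound 2 to compound 1 (0.27 log units; within the scatter), a step inside the usual scatter, so a step of similar size is expected here, though the core of compound 3 is another one and nothing shows that it answers the same way. On that basis compound 4 is estimated at 8500 nM, a step of a 1.8-fold lower number from compound 3 to compound 4 (0.26 log units; within the scatter) from compound 3, spanning 4000 nM to 18000 nM.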

Compound 4, half-maximal inhibitory concentration: 38600 nM
Estimate against measurement, compound 4: 4.5-fold (0.66 log units) below; measured number outside the range, above it.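

In this assay, chloro in place of hydrogen did not carry over from one core to the other: phenyl to 4-chlorophenyl on the core of compound 3 gave a 2.5-fold higher number from compound 3 to compound 4 (0.40 log units; beyond the scatter), and the gap between this step and the earlier one is larger than two such steps would scatter: the same change on two cores in this assay, a 1.9-fold lower number (0.27 log units; within the scatter) from compound 2 to compound 1 and a 2.5-fold higher number (0.40 log units; beyond the scatter) from compound 3 to compound 4, 4.7-fold (0.68 log units) apart, beyond the scatter of two such steps. Only the new step lies beyond the scatter, so the contrast is between no clear effect on one core and a modest weakening on the other, and in this series the effect of this change on one core did not predict its effect on the other. With a single pair on each core, this does not show why the steps differ, and the changed ring also occupies a different part of the molecule in each pair, so the core and the location of the ring cannot be separated.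

On these data alone, whether fluoro, methyl or an amine in place of chloro on the same ring would behave as chloro does remains open. So does the effect of chloro on the other aromatic rings of each core.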